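The source may report more compounds than this note shows. Statements on the series, on what has been measured and on what is new or still open speak of the compounds shown alone.

Of the compounds shown here, two have so far been tested in a functional assay on NCI-H520 cells (Homo sapiens) for inhibition, read by MTT assay, with a stated time of 48 h, tested at 10 uM; a higher number here means more inhibition at the concentration tested (going by the name of the read-out), a lower number less inhibition. Compound 1 `COc1cc(NC(=O)Nc2cc(Nc3ccc(C)c(F)c3)ncn2)cc(OC)c1` stands at 30.6%, and compound 2 `COc1cc(Br)ccc1Nc1cc(NC(=O)Nc2c(Cl)cccc2Cl)ncn1` gives 29.1% in this assay, so the two results lie within the usual scatter of each other and neither can be called the stronger. Compound 3 `COc1cc(NC(=O)Nc2cc(Nc3ccc(OC)c(I)c3)ncn2)cc(OC)c1` has not yet been measured. Its structure differs from compound 1 in one place: 3-iodo-4-methoxyphenyl in place of 3-fluoro-4-methylphenyl on a nitrogen on an aromatic ring. Within the data shown here, no measured pair shows what such a change does here, so a step no larger than the scatter, in either direction, is expected, estimated as a number 1.4 percentage points higher from compound 1 to compound 3 (within the scatter). Compound 3 is therefore expected to reach about 32%, within a range of 15% to 50%.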

Compound 3, a percentage reported as inhibition, at one concentration (the size of the read-out at that concentration, not a potency): 46.5%
Compound 3: middle estimate off by 14.5 percentage points, on the low side, and the stated range covers the measured number.
By their numbers in this assay, from the lowest: compounds 2 and 1 (each within the scatter of the next); then compound 3.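

In this assay, among these compounds, the group on this aromatic nitrogen clearly matters: 3-iodo-4-methoxyphenyl in place of 3-fluoro-4-methylphenyl gives a number 15.9 percentage points higher from compound 1 to compound 3 (beyond the scatter) and is the first step here beyond the scatter. Both ring substituents differ in this swap, so the step cannot be assigned to the iodine or to the methoxy alone. Nothing measured here explains the step. Which of the two substituents carries the step remains open. So does what an amine or a carboxylic acid on this ring would do.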